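A few compounds are considered here, and "the series" means these few. Any claim that something is new, unique, unknown or untested is made for them only; others in the source may bear on it.

Compound 1 `COc1ccc(C2=C(c3ccc(SC)cc3)CC3CCCN3C2=O)cc1Br` carries a 3-bromo-4-methoxyphenyl group on a double-bonded ring carbon of its core. Among the measured compounds shown here, in a functional assay on U-251 cells (Homo sapiens) for cytotoxicity (a lower number here means a stronger inhibitor of growth, a higher number a weaker inhibitor of growth), compound 1 gives 800 nM, which is the highest of the two numbers measured so far. Compound 2 `CSc1ccc(C2=C(c3ccc(C)cc3)C(=O)N3CCCC3C2)cc1`, in which a 4-methylphenyl sits on that carbon, gives 400 nM in this assay, and the step of a 2.0-fold lower number from compound 1 to compound 2 (0.30 log units; within the scatter) lies within the scatter, so the two compounds cannot be told apart on these numbers.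

Compound 3 `CSc1ccc(C2=C(c3ccc(F)cc3)C(=O)N3CCCC3C2)cc1` is not yet measured. It differs from compound 1 as follows: 4-fluorophenyl in place of 3-bromo-4-methoxyphenyl on a double-bonded ring carbon

For the measured compounds named here, the only measured step that bears on this change is the one from compound 1 to compound 2, where the same 3-bromo-4-methoxyphenyl group was exchanged for another small substituted phenyl ring at the same position, with a result within the scatter. A second exchange of this kind, to 4-fluorophenyl, is therefore expected to move the number little, if at all, beyond the scatter. Compound 3 is expected to give about 500 nM in this assay, between 200 nM and 1500 nM, which corresponds to an expected step of a 1.6-fold lower number from compound 1 to compound 3 (0.20 log units; within the scatter).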

Compound 3, concentration for 50% growth inhibition: 90 nM
The estimate for compound 3 lay 5.6-fold (0.74 log units) above the measured number; measured number below the stated range.
By their numbers in this assay, from the lowest: compound 3; then compounds 2 and 1 (each within the scatter of the next).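

In this assay, the group on this double-bonded ring carbon does matter: the change to 4-fluorophenyl gives an 8.9-fold lower number from compound 1 to compound 3 (0.95 log units; beyond the scatter), which the first two compounds had not shown. The clearest comparison is with compound 2, where only one substituent on the aromatic ring differs, fluoro in place of methyl, and this single exchange gives a 4.4-fold lower number from compound 2 to compound 3 (0.65 log units; beyond the scatter). The bromo and methoxy groups are also absent from compound 2, yet a 2.0-fold lower number from compound 1 to compound 2 (0.30 log units; within the scatter) stays within the scatter, so among these three compounds, losing those two groups is not enough on its own to give a step beyond the scatter, while having fluoro rather than methyl on the ring is.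

Nothing available here explains why fluoro and methyl differ so clearly at this position. The compounds shown also leave open whether this step is particular to fluoro or would also appear with a chloro group, a hydroxyl group or an amine on the same phenyl ring.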